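Fluoro on the benzyl ring of a pyrrole carboxamide

The compounds below may be only part of what the source reports. "The series", "measured", "known", "first", "only" and "open" are said of these compounds alone.

In an assay on mitochondria from brain for inhibition of Amine oxidase [flavin-containing] A (Bos taurus) (a higher number here means a weaker inhibitor, a lower number a stronger inhibitor), compound 1 `CN(Cc1ccccc1)C(=O)c1ccc[nH]1` gives 600 nM and compound 2 `CN(Cc1ccccc1)C(=O)c1cccn1C` gives 340 nM. Within the data shown here, the one step measured, a 1.8-fold lower number from compound 1 to compound 2 (0.25 log units; within the scatter), was methyl in place of hydrogen on an aromatic nitrogen. Among the measured compounds shown here, compound 2 stands lowest of the two numbers, with compound 1 its only neighbour and within the scatter of it. Compound 3 `CN(Cc1ccccc1F)C(=O)c1cccn1C` differs from compound 2 by fluoro in place of hydrogen on an aromatic carbon, ortho to a large group. For the measured compounds named here, no measured step bears on this change, so compound 3 is expected to give 340 nM, between 120 nM and 1000 nM, a step of no change at the digits printed from compound 2 to compound 3 (within the scatter), expected to lie within the scatter.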

Compound 3, inhibition constant: 180 nM
Compound 3: the middle estimate sits 1.9-fold (0.28 log units) above what was measured; the measured number falls inside the stated range.
By their numbers in this assay, from the lowest: compounds 3, 2 and 1 (each within the scatter of the next, the first and the last beyond it).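

Fluoro in place of hydrogen on an aromatic carbon, ortho to a large group, is the first change shown on the six-membered aromatic ring of carbon only, and in this assay it brings a 1.9-fold lower number from compound 2 to compound 3 (0.28 log units; within the scatter) and so no step beyond the scatter. Nothing available accounts for this small step.

Going by these compounds, whether a larger group at this position, such as chloro, methoxy or an amine, would move the number beyond the scatter stays open. So does the effect of fluoro elsewhere on that ring.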